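Amide replacement on a cytotoxic quinazoline series

The source may report more compounds than this note shows. Statements on the series, on what has been measured and on what is new or still open speak of the compounds shown alone.

Compound 1 `CNc1ncnc2c(CNc3cc(NC(=O)c4cccc(C(F)(F)F)c4)ccc3C)cccc12`: 433 nM
Compound 2 `CNc1ncnc2c(CNc3cc(NC(=O)c4ccnnc4)ccc3C)cccc12`: 61700 nM
Compound 3 `CNc1ncnc2c(CNc3cc(NC(=O)c4cscn4)ccc3C)cccc12`: 1900 nM

In a functional assay on A375P cells (Homo sapiens) for cytotoxicity, read by MTT assay, with a stated time of 24 h (on this read-out lower numbers stand for stronger inhibition and higher numbers for weaker inhibition), compound 3 stands second highest of the three numbers; compound 1 gives a lower number, a 4.4-fold higher number from compound 1 to compound 3 (0.64 log units; beyond the scatter), and compound 2 a far higher one, a 32-fold lower number from compound 2 to compound 3 (1.51 log units; beyond the scatter). Compound 4 `CNc1ncnc2c(CNc3cc(NC(=O)c4cc(=O)c5ccccc5o4)ccc3C)cccc12` differs from compound 3 in one place: a group of 11 heavy atoms (9 carbon, 2 oxygen; one six-membered aromatic ring of carbon only, one six-membered aromatic ring with 1 hetero atom) in place of a group of 5 heavy atoms (3 carbon, 1 nitrogen, 1 sulfur; one five-membered aromatic ring with 2 hetero atoms), on a carbonyl carbon. Going by the values given here, no measured step involves this entering group, so the bearing steps are only those that swap the amide aryl: a 140-fold higher number from compound 1 to compound 2 (2.15 log units; beyond the scatter) and a 4.4-fold higher number from compound 1 to compound 3 (0.64 log units; beyond the scatter), which show that this position can move the read-out widely in either direction. Given that, compound 4 is expected to land near compound 3 or somewhat lower, with wide uncertainty, a 1.6-fold lower number from compound 3 to compound 4 (0.20 log units; within the scatter). For compound 4 the estimate is 1200 nM, within 250 nM to 8000 nM.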

Compound 4, half-maximal inhibitory concentration: 6 nM
Compound 4: middle estimate off by 200-fold (2.30 log units), on the high side; the whole stated range lies above it.
By their numbers in this assay, from the lowest: compound 4; then compound 1; then compound 3; then compound 2.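

In this assay, going by these compounds alone, this position proves to reach much stronger values than the earlier compounds showed: the entering group of 11 heavy atoms gives a 320-fold lower number from compound 3 to compound 4 (2.50 log units; beyond the scatter) and also a 72-fold lower number from compound 1 to compound 4 (1.86 log units; beyond the scatter), so it surpasses the 3-(trifluoromethyl)phenyl amide. Swapping this one group now spans a 10000-fold lower number from compound 2 to compound 4 (4.01 log units; beyond the scatter). The count of hydrogen-bond acceptors does not separate the entering group from 1,3-thiazol-4-yl, as both groups have the same count. Nothing available gives a reason for the gain. On these data alone, it remains open whether the gain needs both rings of the entering group, and what an amine or a carboxylic acid on that group would do.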